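This account rests on a few compounds, and the source may have more. Where it says the series, first, only, none or still open, it means among the compounds named here.

Measured in an ADME assay on HepG2 cells (Homo sapiens) for cytotoxicity, read by luminescence, with a stated time of 72 h (on this read-out lower numbers stand for an effect already at smaller amounts and higher numbers for an effect only at larger amounts of compound), are:
Compound 1 `CCOC(=O)c1c(-c2cccc(OC)c2)[nH]c2cc(Cl)c(OC)cc2c1=O` gives > 21500 nM (a limit)
Compound 2 `CCOC(=O)c1c(-c2cccc(-c3ccccc3)c2)[nH]c2cc(OC)c(F)cc2c1=O` gives > 21500 nM (a limit)
Compound 3 `COc1cc2[nH]c(-c3cccc(Oc4ccccc4)c3)c(C(=O)NCCCN3CCCC3)c(=O)c2cc1F` gives > 21500 nM (a limit)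

Compound 3 thus has a limit of the assay and not a number. It stands with compounds 1 and 2 at the limit of > 21500 nM in this assay, at which 3 of the 3 values shown sit, and has no rank among them. Compound 4 `COc1cc2[nH]c(-c3cccc(Oc4ccccc4)c3)c(C(=O)OCCO)c(=O)c2cc1F` differs from compound 3 by a single change: 2-hydroxyethoxy in place of (3-(pyrrolidin-1-yl)propyl)amino on a carbonyl carbon on that carbonyl carbon. For the measured compounds named here, no step between measured compounds is available to size this change. With compound 3 at > 21500 nM as a limit, no step beyond the scatter is expected in this assay and the expected step that the limit leaves unreadable from compound 3 to compound 4 stays small. For compound 4 the estimated value is 25000 nM with a range from 12000 nM to 50000 nM and it is expected to be reported only as a limit.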

Compound 4, half-maximal effective concentration: > 21500 nM
Compound 4: only a limit was reported (the forecaster's own chance of this, stated with the estimate: 85%); the middle value is on the limit's open side.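

No step can be read from compound 3 to compound 4, since both are reported only as limits: the limit of > 21500 nM in this assay, at which 4 of the 4 values shown sit.

The compounds shown leave open at what concentration any of them reaches a half-maximal effect in this assay, and whether 2-hydroxyethoxy and (3-(pyrrolidin-1-yl)propyl)amino differ there at all.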